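Tribromophenyl ether returns to the toxicity level of compound 1

The source may report more compounds than this note shows. Statements on the series, on what has been measured and on what is new or still open speak of the compounds shown alone.

Measured compounds:
Compound 1 `Cc1cc(Br)c(Oc2nc(Nc3ccc(C#N)cc3)nc3ccccc23)c(Br)c1`: 25000 nM
Compound 2 `N#Cc1ccc(Nc2nc(Oc3ccccc3)c3ccccc3n2)cc1`: 370000 nM

Of the compounds shown here, two have so far been measured in an ADME assay on MT4 cells (Homo sapiens) for cytotoxicity, read by MTT assay, with a stated time of 4 days; on this read-out lower numbers stand for higher toxicity in this test and higher numbers for lower toxicity in this test. Compound 1 `Cc1cc(Br)c(Oc2nc(Nc3ccc(C#N)cc3)nc3ccccc23)c(Br)c1` gives 25000 nM. Going by the values given here, compound 2 `N#Cc1ccc(Nc2nc(Oc3ccccc3)c3ccccc3n2)cc1` gives 370000 nM, the highest of the two numbers, and its only neighbour is compound 1, which sits a step below it a 15-fold higher number from compound 1 to compound 2 (1.17 log units; beyond the scatter). That step came from exchanging the 2,6-dibromo-4-methylphenyl on the ether oxygen for a plain phenyl.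

Compound 3 `N#Cc1ccc(Nc2nc(Oc3c(Br)cc(Br)cc3Br)c3ccccc3n2)cc1` has not yet been measured. It differs from compound 2 in one place: 2,4,6-tribromophenyl in place of phenyl on an oxygen on an aromatic ring. Among the compounds with values here, the change runs in the opposite sense to the one measured step, bringing a heavily brominated phenyl back onto the same oxygen, and it is that step a 15-fold higher number from compound 1 to compound 2 (1.17 log units; beyond the scatter) which bears on the question. A return towards the number of compound 1, and so a lower number in this assay than for compound 2, is therefore expected for compound 3, with the step of a 12-fold lower number from compound 2 to compound 3 (1.09 log units; beyond the scatter) estimated to be of similar size but reversed. The estimate for compound 3 is 30000 nM, with a range from 10000 nM to 120000 nM.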

Compound 3, half-maximal cytotoxic concentration: 58000 nM
For compound 3 the middle estimate is 1.9-fold (0.29 log units) below the measured one, and the stated range covers the measured number.
By their numbers in this assay, from the lowest: compound 1; then compound 3; then compound 2.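

In this assay, 2,4,6-tribromophenyl in place of phenyl on the oxygen gives a 6.4-fold lower number from compound 2 to compound 3 (0.80 log units; beyond the scatter) and so shows that a second brominated phenyl on this oxygen also sits lower than the plain phenyl of compound 2, although this step is smaller than the earlier 15-fold higher number from compound 1 to compound 2 (1.17 log units; beyond the scatter) in the opposite direction. The two brominated compounds do not coincide either: bromo in place of methyl on an aromatic carbon gives a 2.3-fold higher number from compound 1 to compound 3 (0.37 log units; beyond the scatter) and so shows that the number still responds to a change on the brominated ring, not only to the presence of bromine on it. Nothing available here bears on what lies behind these steps.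

Going by these compounds, whether the lower numbers belong to bromine itself remains open, as does how a phenyl carrying chloro, methoxy or an amine on this oxygen would stand against compound 2 and compound 3. On these data alone, it is also open whether a phenyl with a single bromo would fall between compound 2 and compound 3, or whether the number does not follow the count of bromines at all.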